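Replacing the propyl ether of compound 3 with a carbamate

A few compounds are considered here, and "the series" means these few. Any claim that something is new, unique, unknown or untested is made for them only; others in the source may bear on it.

Of the compounds shown here, three share a core and have been tested in a functional assay on PANC-1 cells (Homo sapiens) for inhibition, read by MTT assay, with a stated time of 24 h, tested at 10 uM; on this read-out higher numbers stand for more inhibition at the one concentration tested (going by the name of the read-out) and lower numbers for less inhibition. Compound 1 `CCOc1cc(=O)n(CCCO)c2c1CC(C/C=C(\C)CCC=C(C)C)C(C)(C)C2` gives 0.8%. Compound 2 `CC(C)=CCC/C(C)=C/CC1Cc2c(OCCCNC(=O)c3ccco3)cc(=O)n(CCCO)c2CC1(C)C` gives 2.8% in this assay, and compound 3 `COc1ccc(OCCCOc2cc(=O)n(CCCO)c3c2CC(C/C=C(\C)CCC=C(C)C)C(C)(C)C3)cc1` gives 0%. Compound 3 stands at the lowest of the three numbers, but its distance to the others is small: the step of a number 0.8 percentage points lower from compound 1 to compound 3 (within the scatter) and the step of a number 2.8 percentage points lower from compound 2 to compound 3 (within the scatter) are both within the scatter, as is the step of a number 2 percentage points higher from compound 1 to compound 2 (within the scatter).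

Compound 4 `COc1ccccc1NC(=O)Oc1cc(=O)n(CCCO)c2c1CC(C/C=C(\C)CCC=C(C)C)C(C)(C)C2` differs from compound 3 at the same oxygen that varies across the other three: (2-methoxyphenyl)carbamoyl in place of 3-(4-methoxyphenoxy)propyl on an oxygen on an aromatic ring. Within the data shown here, the steps that bear on this change, those from compound 1 and compound 2 to compound 3, were all within the scatter, and no substituent at this position has moved the number by more than that. Compound 4 is therefore expected to show no step beyond the scatter, a number 1.5 percentage points higher from compound 3 to compound 4 (within the scatter). The estimate for compound 4 is 1.5%, with a range from 0% to 10%.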

Compound 4, a percentage reported as inhibition, at one concentration (the size of the read-out at that concentration, not a potency): 0%
The estimate for compound 4 lay 1.5 percentage points above the measured number; low and high end bracket the measured number.
By their numbers in this assay, from the lowest: compounds 3, 4, 1 and 2 (each within the scatter of the next).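

In this assay, putting (2-methoxyphenyl)carbamoyl in place of 3-(4-methoxyphenoxy)propyl on the oxygen gives no change at the digits printed from compound 3 to compound 4 (within the scatter), so the read-out stays flat even when the saturated chain gives way to a carbamoyl group, which brings a hydrogen-bond donor and a double bond outside aromatic rings. The same holds against the two other ethers, with a number 0.8 percentage points lower from compound 1 to compound 4 (within the scatter) and a number 2.8 percentage points lower from compound 2 to compound 4 (within the scatter), so all four groups on this oxygen now lie within the scatter of each other. Nothing available explains this flat result.

The compounds shown leave open whether any group on this oxygen can move the number beyond the scatter, for instance a longer chain ending in a primary amine or a carboxylic acid. They also leave open whether a carbamoyl group carrying a different aryl or alkyl group would behave like compound 4.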